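Cyano in place of nitro: working notes on the series

This account rests on a few compounds, and the source may have more. Where it says the series, first, only, none or still open, it means among the compounds named here.

- compound 1 `O=S(=O)(Nc1cccc2c(Cl)c[nH]c12)c1ccc(Cl)cc1` gives 8.8 ug/mL
- compound 2 `O=[N+]([O-])c1ccc(S(=O)(=O)Nc2cccc3c(Cl)c[nH]c23)cc1` gives 14 ug/mL
- compound 3 `N#Cc1ccc(S(=O)(=O)Nc2cccc3c(Cl)c[nH]c23)cc1` is not yet measured

In a functional assay on KB cells (Homo sapiens) for antiproliferative activity, read by colorimetric assay and MTT assay (on this read-out higher numbers stand for weaker inhibition and lower numbers for stronger inhibition), compound 2 stands level with compound 1 , the measured step being a 1.6-fold higher number from compound 1 to compound 2 (0.20 log units; within the scatter) for nitro in place of chloro on an aromatic carbon. The next change, to compound 3 , is cyano in place of nitro on an aromatic carbon on the same kind of aromatic carbon, para to a large group. Among the compounds with values here, the only measured step to go on is a 1.6-fold higher number from compound 1 to compound 2 (0.20 log units; within the scatter), so no step beyond the scatter is expected in this assay, in either direction. The estimated step is a 1.3-fold lower number from compound 2 to compound 3 (0.10 log units; within the scatter), which stays inside the scatter. The estimate for compound 3 is 11 ug/mL, with an expected range from 5 ug/mL to 24 ug/mL.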

Compound 3, half-maximal inhibitory concentration: 11 ug/mL
Compound 3: the middle estimate sits on the measured number at the digits printed, and the stated range covers the measured number.
By their numbers in this assay, from the lowest: compounds 1, 3 and 2 (each within the scatter of the next).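

In this assay, cyano in place of nitro gives a 1.3-fold lower number from compound 2 to compound 3 (0.10 log units; within the scatter), and cyano in place of chloro gives a 1.3-fold higher number from compound 1 to compound 3 (0.10 log units; within the scatter). On this aromatic carbon, para to a large group, chloro, nitro and cyano therefore all read within the scatter of one another, so the third group adds no separation to the series. Within the data shown here, no evidence on the compounds bears on this result.

From the compounds shown here alone, whether an amine, a carboxylic acid or a longer chain on this carbon would read the same remains open, as does the effect of changes elsewhere on the shared core.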